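This account rests on a few compounds, and the source may have more. Where it says the series, first, only, none or still open, it means among the compounds named here.

The measured compounds and their values in an ADME assay on RAW264.7 cells (Mus musculus) for cytotoxicity, read by MTT assay, with a stated time of 72 h, tested at 100 uM; on this read-out lower numbers stand for a weaker effect and higher numbers for a stronger effect at the one concentration tested:
compound 1 `O=C(Cn1c(=O)oc2cc(Cl)ccc21)NCc1cccs1`: 53.6%
compound 2 `O=C(Cn1c(=O)oc2cc(Cl)ccc21)Nc1cc(C(F)(F)F)ccc1Cl`: 12.1%
compound 3 `O=C(Cn1c(=O)oc2cc([N+](=O)[O-])ccc21)NCc1cccs1`: 41%

Compound 1 and compound 3 differ in a single place: nitro in place of chloro on an aromatic carbon. In this assay this change made the step of a number 12.6 percentage points lower from compound 1 to compound 3 (beyond the scatter). Compound 2 shares the core of compound 1, but the difference between the two on the amide side is not broken down here. In this assay compound 2 stands lowest of the three; the nearest value is that of compound 3 and the furthest that of compound 1, both gaps lying beyond the usual scatter.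

Compound 4 `O=C(Cn1c(=O)oc2cc([N+](=O)[O-])ccc21)Nc1cc(C(F)(F)F)ccc1Cl` has not yet been measured in this assay. It arises from compound 2 by nitro in place of chloro on an aromatic carbon, the same change that carries compound 1 to compound 3; among the compounds shown it occurs twice. The expectation for compound 4 rests on two things. First, compound 2 already gives a low read-out of 12.1%, so there is little room for a further fall. Second, because the step of a number 12.6 percentage points lower from compound 1 to compound 3 (beyond the scatter) pointed downward, compound 4 is expected to move by a number 7.1 percentage points lower from compound 2 to compound 4 (within the scatter). The estimate for compound 4 is therefore 5%, with a plausible range from 0% to 20%.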

Compound 4, a percentage reported as inhibition, at one concentration (the size of the read-out at that concentration, not a potency): 31.6%
Beside the measured number, compound 4's estimate is 26.6 percentage points below it; the whole stated range lies below it.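

In this assay, nitro in place of chloro on the amide side of compound 2 gave a number 19.5 percentage points higher from compound 2 to compound 4 (beyond the scatter), so the change did not repeat what it had done on the amide side of compound 1. Set together, the two steps point in opposite directions, and the gap between them exceeds what repeated measurement would be expected to produce: the same change on two cores in this assay, a number 12.6 percentage points lower (beyond the scatter) from compound 1 to compound 3 and a number 19.5 percentage points higher (beyond the scatter) from compound 2 to compound 4, 32.1 percentage points apart, beyond the scatter of two such steps This shows that, within these two pairs, neither the direction nor the size of the step could be carried from one amide side to the other, but with only two pairs it does not establish a general rule for the series, nor does it say what in the amide side sets the direction.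

The compounds shown leave open which feature of the two amide sides goes with the reversal, and whether the two steps would keep their opposite directions at concentrations other than the single one tested. They also leave open how another group on the same aromatic carbon, such as a nitrile, an amine or a carboxylic acid, would behave on each of the two amide sides.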